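A fluoro step repeated on a second core

The source may report more compounds than this note shows. Statements on the series, on what has been measured and on what is new or still open speak of the compounds shown alone.

Compound 1, `O=C(CSc1nc2c(c(=O)n1-c1ccccc1)SCC2)Nc1nc2ccc(Cl)cc2s1`, gives 40 nM in an assay on L cells for inhibition of Protein-serine O-palmitoleoyltransferase porcupine (Mus musculus), read by reporter gene assay, with a stated time of 24 h; on this read-out higher numbers stand for an effect only at larger amounts of compound and lower numbers for an effect already at smaller amounts.
Compound 2, `O=C(CSc1nc2c(c(=O)n1-c1ccc(F)cc1)SCC2)Nc1nc2ccc(Cl)cc2s1`, gives 175 nM.
Compound 3, `O=C(CSc1nc2c(c(=O)n1-c1ccccc1)SCC2)Nc1nc2ccc(C(F)(F)F)cc2s1`, gives 40 nM.

Two of these three compounds share one core, and the third shows how that core tolerates a change at its fused ring. Compound 1 and compound 2 differ only in the change (fluoro in place of hydrogen on an aromatic carbon), and that change made the step of a 4.4-fold higher number from compound 1 to compound 2 (0.64 log units; beyond the scatter). Compound 1 and compound 3 differ in the change (trifluoromethyl in place of chloro on an aromatic carbon), and this difference between the two cores made the step of no change at the digits printed from compound 1 to compound 3 (within the scatter), so compound 3 stands level with compound 1.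

Compound 4, `O=C(CSc1nc2c(c(=O)n1-c1ccc(F)cc1)SCC2)Nc1nc2ccc(C(F)(F)F)cc2s1`, has not yet been measured. It differs from compound 3 by fluoro in place of hydrogen on an aromatic carbon, which is the same change that turns compound 1 into compound 2, set on the core of compound 3 instead. The surroundings of the place of the change are described in the same words for both pairs, so this is the same change, not merely one of the same kind.

Because the step of no change at the digits printed from compound 1 to compound 3 (within the scatter) leaves the two cores level, the expectation is that the fluoro step repeats itself, and the step from compound 3 to compound 4 is estimated at a 4.4-fold higher number from compound 3 to compound 4 (0.64 log units; beyond the scatter), to be set beside the earlier one, a 4.4-fold higher number from compound 1 to compound 2 (0.64 log units; beyond the scatter). Among the measured compounds shown here, compound 4 is therefore expected to give about 175 nM, with a likely range from 70 nM to 450 nM, with only two measured pairs to rest on.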

Compound 4, half-maximal effective concentration: 100 nM
Estimate against measurement, compound 4: 1.8-fold (0.24 log units) above, within the range that was stated.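

On the core of compound 3, the phenyl to 4-fluorophenyl change again raised the number in this assay, with a 2.5-fold higher number from compound 3 to compound 4 (0.40 log units; beyond the scatter), and the two fluoro steps agree as closely as two such steps can be told apart: the same change on two cores in this assay, a 4.4-fold higher number (0.64 log units; beyond the scatter) from compound 1 to compound 2 and a 2.5-fold higher number (0.40 log units; beyond the scatter) from compound 3 to compound 4, 1.8-fold (0.24 log units) apart, within the scatter of two such steps. The trifluoromethyl in place of chloro change, read on the two fluorinated compounds, gives a 1.8-fold lower number from compound 2 to compound 4 (0.24 log units; within the scatter), and it too looks the same on both cores: the same change on two cores in this assay, no change at the digits printed (within the scatter) from compound 1 to compound 3 and a 1.8-fold lower number (0.24 log units; within the scatter) from compound 2 to compound 4, 1.8-fold (0.24 log units) apart, within the scatter of two such steps. Across these four compounds, then, each change can be carried from one core to the other with no detectable dependence on the core, but this rests on just two pairs per change, so it does not fix the exact size of either step and says nothing of cores beyond these.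

The compounds shown leave open whether a methyl or methoxy group in place of the fluoro on the phenyl ring would shift the number in the same direction on both cores. They also leave open whether an amine or a carboxylic acid in place of the chloro or trifluoromethyl would leave the fluoro step as it stands here in this assay.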